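Working notes: oral bioavailability, step from compound 3 to compound 4

The source may hold more compounds than are shown below. What is called first, only, known or untested is meant among the compounds shown, and "the series" means these compounds.

Three members of the series have numbers in an ADME assay on the whole organism (Rattus norvegicus) for pharmacokinetics, at a dose of 1 mg/kg by the oral route; on this read-out higher numbers stand for higher oral bioavailability and lower numbers for lower oral bioavailability. Compound 1 `O=C(C1=C(O)C(=O)N(c2ccc(-c3ccon3)cc2)C1C1CCCCC1)c1ccc(CO)cc1` gives 6.7%, compound 2 `CNC(=O)c1ccc(C(=O)C2=C(O)C(=O)N(c3ccc(-c4ccon4)cc3)C2C2CCCCC2)cc1` gives 1.6% and compound 3 `CCC(CC)C1C(C(=O)c2ccc(OC)cc2)=C(O)C(=O)N1c1ccc(-c2ccon2)cc1` gives 18.9%. For the measured compounds named here, the single measured step, a number 5.1 percentage points lower from compound 1 to compound 2 (within the scatter), lies within the scatter. Compound 3 stands highest of the three: compound 1 is nearest, lower by a margin beyond the scatter, and compound 2 is furthest, also beyond the scatter. Compound 4 `COc1ccc(C(=O)C2=C(O)C(=O)N(c3ccc(-c4ccon4)cc3)C2c2ccccc2OCCO)cc1` is not yet measured; it differs from compound 3 by 2-(2-hydroxyethoxy)phenyl in place of pentan-3-yl on a saturated ring carbon. Going by the values given here, no measured step touches this saturated ring carbon, so the step from compound 1 to compound 2 does not bear on it directly; compounds 1 and 2, which carry cyclohexyl at that position, simply show lower numbers than compound 3. The change is therefore expected to give a downward step, a number 10.9 percentage points lower from compound 3 to compound 4 (beyond the scatter), in this assay, though its size is uncertain. Compound 4 is estimated at 8%, within a range of 2% to 22%.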

Compound 4, oral bioavailability: 9%
Estimate against measurement, compound 4: 1 percentage points below; the measured number falls inside the stated range.
By their numbers in this assay, from the lowest: compounds 2, 1, 4 and 3 (each within the scatter of the next, the first and the last beyond it).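

In this assay, for the compounds shown here, the saturated ring carbon next to the ring nitrogen now has its first measured step, a number 9.9 percentage points lower from compound 3 to compound 4 (within the scatter), and this is the only reading of the change at this position. The exchange takes the substituent from 5 to 10 heavy atoms, replaces an open chain with an aromatic ring, and brings in a hydrogen-bond donor and 2 hydrogen-bond acceptors, yet the step stays within the scatter, so these additions together do not give a clear change on this read-out. Nothing on hand explains the step.

The compounds shown do not separate the contribution of the aromatic ring from that of the hydroxyethoxy chain. Going by these compounds, how a plain phenyl, or an amine or a carboxylic acid at the end of that chain, would read at this position remains open.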